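Bcl-2 series: carboxyphenyl to carboxy-nitrophenyl on the ether

This account rests on a few compounds, and the source may have more. Where it says the series, first, only, none or still open, it means among the compounds named here.

Compound 1 `O=C(Nc1ccc(O)c(C(=O)O)c1)c1ccc(/C=C2\SC(=S)N(c3ccccc3)C2=O)cc1` gives > 10000 nM in an assay on isolated protein for inhibition of Apoptosis regulator Bcl-2 (Homo sapiens), read by fluorescence polarization (a lower number here means a stronger inhibitor, a higher number a weaker inhibitor), which is a limit of the assay.
Compound 2 `COc1ccccc1N1C(=O)/C(=C/c2ccc(OCc3ccc(C(=O)O)cc3)cc2)SC1=S` gives 2000 nM in this assay.
Compound 3 `O=C(O)c1ccc(COc2ccc(/C=C3\SC(=S)N(c4ccc([N+](=O)[O-])cc4)C3=O)cc2)cc1` gives > 10000 nM in this assay, again a limit of the assay.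

Compound 3 thus sits at the limit of > 10000 nM in this assay, at which 2 of the 3 values shown sit, and only compound 2 gives a number. Among the compounds with values here, the step of an at least 5.0-fold higher number from compound 2 to compound 3 (0.69 log units; beyond the scatter) is the one measured step, and it changed the aryl on the ring nitrogen, not the ether arm. Compound 4 `O=C(O)c1ccc([N+](=O)[O-])c(COc2ccc(/C=C3\SC(=S)N(c4ccc([N+](=O)[O-])cc4)C3=O)cc2)c1` differs from compound 3 by 5-carboxy-2-nitrophenyl in place of 4-carboxyphenyl on a saturated chain carbon bound to an oxygen on an aromatic ring. Within the data shown here, no measured step touches this place, so no expectation beyond the scatter follows from the data. Compound 4 is therefore expected to stay near the limit, with an estimated step that the limit leaves unreadable from compound 3 to compound 4. The estimate for compound 4 in this assay is 15000 nM, in the range 5000 nM to 50000 nM.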

Compound 4, inhibition constant: 3100 nM
Compound 4: middle estimate off by 4.8-fold (0.68 log units), on the high side; the measured number lies below the stated range.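

The ether arm is a second place that moves the number: 5-carboxy-2-nitrophenyl in place of 4-carboxyphenyl on a saturated chain carbon bound to an oxygen on an aromatic ring gives an at least 3.2-fold lower number from compound 3 to compound 4 (0.50 log units; beyond the scatter). Within the data shown here, until now, the only readable step lay on the ring nitrogen, and this one keeps the 4-nitrophenyl there. The step is a bound rather than a size, as compound 3 carries a limit of the assay: the limit of > 10000 nM in this assay, at which 2 of the 4 values shown sit.

Still open, from the compounds shown here alone, is whether the added nitro group alone accounts for the step, or whether an amine or a nitrile there would serve as well. Also open, going by these compounds, is whether the same change holds with 2-methoxyphenyl on the ring nitrogen.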